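The source may hold more compounds than are shown below. What is called first, only, known or untested is meant among the compounds shown, and "the series" means these compounds.

Of the compounds shown here, three have been measured in a functional assay (muscle tissue) with Cavia porcellus as the target; on this read-out higher numbers stand for an effect only at larger amounts of compound and lower numbers for an effect already at smaller amounts. Compound 1 `COC(=O)C1=C(C)NC(C)=C(C(=O)OC)C1c1ccccc1` gives 28.2 nM in this assay. Compound 2 `COC(=O)C1=C(C)N=C(C)/C(=C(\O)OC)C1c1cc(OC)c(OC)cc1OC` gives 1000000 nM. Compound 3 `COC(=O)C1=C(C)N=C(C)/C(=C(\O)OC)C1c1ccccc1I` gives 46.8 nM, which is the second highest of the three numbers: its nearest neighbour is compound 1, whose value lies within the scatter of repeated measurements, while compound 2 stands far from it, well beyond the scatter. No pair among these three compounds differs in only one place, so no single step between measured compounds can be read off.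

Compound 4 `CCc1ccccc1C1C(C(=O)OC)=C(C)N=C(C)/C1=C(\O)OC` has not yet been measured in this assay. It differs from compound 3 in one place: ethyl in place of iodo on an aromatic carbon. The group that leaves and the group that enters are both small, uncharged, and without donors or acceptors, and they sit at the same place on the phenyl ring. Going by the values given here, nothing among the measured compounds shows what such an exchange does here. The step from compound 3 to compound 4 is therefore expected to be small, a 1.0-fold lower number from compound 3 to compound 4 (0.02 log units; within the scatter), with no clear direction beyond the scatter. Compound 4 is estimated to give 45 nM in this assay, within a range from 12 nM to 180 nM.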

Compound 4, half-maximal effective concentration: 6.46 nM
Beside the measured number, compound 4's estimate is 7.0-fold (0.84 log units) above it; the measured number lies below the stated range.
By their numbers in this assay, from the lowest: compound 4; then compounds 1 and 3 (each within the scatter of the next); then compound 2.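

In this assay the exchange of iodo for ethyl on an aromatic carbon gives a 7.2-fold lower number from compound 3 to compound 4 (0.86 log units; beyond the scatter) and so moves the read-out towards an effect at smaller amounts. Going by these compounds alone, this is the first step in one place that can be read here, and it shows that the position ortho to a large group responds to an exchange between two uncharged groups, neither with hydrogen-bond donors or acceptors. Nothing available accounts for the size or direction of this step. On these data alone, it remains open whether a longer chain such as propyl would lower the number further at this place, or whether an amine or a carboxylic acid would be accepted there. Also open, as far as these compounds go, is how a methoxy group at this place would compare with ethyl and iodo.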